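Working notes: the acyl chain from compound 2 to compound 3

The source may report more compounds than this note shows. Statements on the series, on what has been measured and on what is new or still open speak of the compounds shown alone.

Measured so far in a functional assay on HCT-116 cells (Homo sapiens) for inhibition, read by MTT assay, with a stated time of 48 h; on this read-out lower numbers stand for stronger inhibition and higher numbers for weaker inhibition:
- compound 1 (`COc1ccc(CN(C(C)=O)c2cc(OC)c(OC)c(OC)c2)cc1O`) at (270 nM)
- compound 2 (`COc1ccc(CN(C(=O)CCCCCl)c2cc(OC)c(OC)c(OC)c2)cc1O`) at (220 nM)

Compound 2 at (220 nM) cannot be separated from compound 1 on these numbers, since the two values lie within the scatter of each other. The next compound is compound 3 (`COc1ccc(CN(C(=O)/C=C/CBr)c2cc(OC)c(OC)c(OC)c2)cc1O`), which keeps the shared core and changes only the group on the carbonyl carbon: 3-bromoprop-1-en-1-yl in place of 4-chlorobutyl on a carbonyl carbon. In short, 3-bromoprop-1-en-1-yl stands in place of 4-chlorobutyl on a carbonyl carbon.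

For the measured compounds named here, only one measured step bears on this change: a 1.2-fold lower number from compound 1 to compound 2 (0.09 log units; within the scatter). It too alters the chain on the carbonyl side, and it stays within the scatter. Going by the values given here, no measured compound carries the 3-bromoprop-1-en-1-yl group, so the data give no direct read on it, and the uncertainty is wide. With so small a precedent, no shift beyond the scatter is expected in this assay and the expected step is a 1.1-fold lower number from compound 2 to compound 3 (0.04 log units; within the scatter) as estimated here. The expected value for compound 3 is 200 nM with an estimated range from 60 nM to 650 nM as its bounds.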

Compound 3, half-maximal inhibitory concentration: 59 nM
For compound 3 the middle estimate is 3.4-fold (0.53 log units) above the measured one, outside the stated range (below it).
By their numbers in this assay, from the lowest: compound 3; then compounds 2 and 1 (each within the scatter of the next).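

Working notes on the result for compound 3

In this assay the group on the carbonyl carbon now moves the read-out beyond the scatter, with a 3.7-fold lower number from compound 2 to compound 3 (0.57 log units; beyond the scatter) and a 4.6-fold lower number from compound 1 to compound 3 (0.66 log units; beyond the scatter), whereas the step from the methyl of compound 1 to the 4-chlorobutyl of compound 2 did not separate those two compounds. Compound 3 is therefore the most potent of the three in this read-out, and 3-bromoprop-1-en-1-yl is the only group shown on the carbonyl carbon that stands apart from the others, though the change brings in a double bond, replaces chlorine with bromine and alters the chain length all at once. No supporting measurement is available to explain this gain in potency.

The compounds shown leave open which of these three differences carries the step, and a saturated 3-bromopropyl group, a 3-chloroprop-1-en-1-yl group and a plain prop-1-en-1-yl group on the same carbonyl carbon would pull them apart. From the compounds shown here alone, it also remains open whether the gain survives with the bromine replaced by an amine or a hydroxyl group, or with a longer alkenyl chain.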